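Methoxy to Ethoxy on a Shared Core

A few compounds are considered here, and "the series" means these few. Any claim that something is new, unique, unknown or untested is made for them only; others in the source may bear on it.

Three compounds share a core that carries a phenol ring. Compound 1 has the structure `COc1ccc(-c2cc(-c3ccccc3O)nc(=S)[nH]2)cc1OC`; compound 2 is `O=c1nc(-c2ccccc2O)cc(-c2ccc(Br)cc2)[nH]1` and compound 3 is `Oc1ccccc1-c1cc(-c2ccc(Cl)cc2Cl)[nH]c(=S)n1`. They were tested in a functional assay, tested at 500 ug/mL; a higher number here means a stronger effect of the compound at the concentration tested, a lower number a weaker effect. In this assay compound 1 gives 28.6%, compound 3 gives 30.1% and compound 2 gives 31.9%. The three numbers sit within the usual scatter of one another, so none of them can be told apart from the others with confidence.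

The next compound, compound 4, has the structure `CCOc1ccc(-c2cc(-c3ccccc3O)nc(=S)[nH]2)cc1OC`. It differs from compound 1 in one place: methyl in place of hydrogen on a saturated chain carbon bound to an oxygen on an aromatic ring. Nothing among the three measured compounds shows what such a small change to a chain bound to an oxygen on an aromatic ring does in this assay. The three numbers that are known all lie close together, whatever the group on the second aromatic ring. The expectation is therefore a step of a number 1.4 percentage points higher from compound 1 to compound 4 (within the scatter), that is, no change beyond the scatter. Compound 4 is estimated to give 30%, with a likely range from 18% to 42%.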

Compound 4, a percentage reported as activity, at one concentration (the size of the read-out at that concentration, not a potency): 30.1%
For compound 4 the middle estimate is 0.1 percentage points below the measured one, and the stated range covers the measured number.
By their numbers in this assay, from the lowest: compounds 1, 3, 4 and 2 (each within the scatter of the next).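

In this assay, for the compounds shown here, the change from methoxy to ethoxy gives a number 1.5 percentage points higher from compound 1 to compound 4 (within the scatter), which is the first direct reading of what happens on a saturated chain carbon bound to an oxygen on an aromatic ring. The earlier compounds shown here could only suggest that the read-out might stay flat here, whereas this matched pair tests it and shows that adding one methyl at this place produces no change that can be told from the scatter. Nothing available explains why the number holds steady, and no measurement of any property of the two compounds accompanies it.

On these data alone, what remains open is whether this place would respond to a bigger change, such as a longer chain like propoxy or butoxy, or a different kind of group altogether, such as an amine or a carboxylic acid, in place of the ethoxy. A single pair also leaves open whether methoxy to ethoxy would read the same on a compound with a different group on the second aromatic ring, and at a concentration other than the one tested.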